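The compounds below may be only part of what the source reports. "The series", "measured", "known", "first", "only" and "open" are said of these compounds alone.

Measured so far in an ADME assay for metabolic stability, read by LC-MS, with a stated time of 3 h, at pH 6.5, tested at 50 uM; a lower number here means that less of the compound is left, a higher number that more of the compound is left:
- compound 1 `C[C@@H](O)[C@H]1C(=O)N2C(C(=O)OCOC(=O)C(C)(C)C)=C(S[C@@H]3CN[C@H](C(=O)Nc4cccc(C(=O)O)c4)C3)[C@H](C)[C@H]12` gives > 95%, a limit of the assay.
- compound 2 `CCC(CC)C(=O)OCOC(=O)C1=C(S[C@@H]2CN[C@H](C(=O)Nc3cccc(C(=O)O)c3)C2)[C@H](C)[C@@H]2[C@@H]([C@@H](C)O)C(=O)N12` gives > 95%, a limit of the assay.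

Compound 2 therefore stands at the limit of > 95% in this assay, at which 2 of the 2 values shown sit; the step that the two limits leave unreadable from compound 1 to compound 2 is unreadable. Compound 3 `COC(=O)OCOC(=O)C1=C(S[C@@H]2CN[C@H](C(=O)Nc3cccc(C(=O)O)c3)C2)[C@H](C)[C@@H]2[C@@H]([C@@H](C)O)C(=O)N12` differs from compound 2 by methoxy in place of pentan-3-yl on a carbonyl carbon. No measured step bears on a methoxy entering at this place, and the one step shown gives no size to work from, so no shift beyond the scatter is expected in this assay. Compound 3 is estimated at 92%, between 75% and 99%. The step expected is a number at least 3 percentage points lower from compound 2 to compound 3 (that floor lies within the scatter).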

Compound 3, percent of the compound remaining: > 95%
Compound 3 ended at the assay's limit (the forecaster's own chance of this, stated with the estimate: 55%); middle value at least 3 percentage points away from the limit.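

No step among compound 1, compound 2 and compound 3 can be read in this assay, where all three values are limits: the limit of > 95% in this assay, at which 3 of the 3 values shown sit.

From the compounds shown here alone, whether tert-butyl, pentan-3-yl and methoxy on this carbonyl carbon differ at all in the percent of compound remaining stays open.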